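Amide variation on the shared core, compound 2 to compound 3

The compounds below may be only part of what the source reports. "The series", "measured", "known", "first", "only" and "open" are said of these compounds alone.

Measured so far:
compound 2 `CC(=O)N1CCc2nc(C#Cc3ccccc3)sc2C1` — 90 nM
compound 1 `Fc1cccc(C#Cc2nc3c(s2)CN(C2CCOC2)CC3)c1` — 400 nM

In an assay on HEK293 cells for negative allosteric modulation of metabotropic glutamate receptor 5 (Homo sapiens), read by FLIPR, with a stated time of 1 h (on this read-out higher numbers stand for weaker inhibition and lower numbers for stronger inhibition), compound 2 gives 90 nM, the lowest of the two numbers; compound 1 gives 400 nM, a higher number, and the gap between them lies beyond the scatter. Compound 3 `N#Cc1cccc(C(=O)N2CCc3nc(C#Cc4ccccc4)sc3C2)c1` is not yet measured; it differs from compound 2 by 3-cyanophenyl in place of methyl on a carbonyl carbon. Going by the values given here, no measured pair in the set shows a change of this kind, so nothing here anchors the size of the step. The step is expected to be modest, a 1.7-fold higher number from compound 2 to compound 3 (0.22 log units; within the scatter), tending if anything toward a weaker number. Compound 3 is estimated at 150 nM, with a range of 40 nM to 600 nM.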

Compound 3, half-maximal inhibitory concentration: > 10000 nM
Compound 3: a limit, no number (the forecaster's own chance of this, stated with the estimate: 5%); at least 66-fold (1.82 log units) between middle value and limit.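

Going by these compounds alone, on the carbonyl carbon whose other neighbour is the ring amide nitrogen, the single change to 3-cyanophenyl in place of methyl gives, in this assay, an at least 110-fold higher number from compound 2 to compound 3 (2.04 log units; beyond the scatter). Within the data shown here, this is the first step read, and it shows that this place on the shared core is not indifferent to its substituent. The result for compound 3 is a limit and not a number: the limit of > 10000 nM in this assay, at which 1 of the 3 values shown sits.

The compounds shown do not separate the contribution of the phenyl ring from that of the nitrile. Also open, on these data alone, is how an unsubstituted phenyl, an ethyl or a methoxymethyl group on this carbonyl carbon would read.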